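Aryl sulfone series: clearance notes, compound 3 outlook

This account rests on a few compounds, and the source may have more. Where it says the series, first, only, none or still open, it means among the compounds named here.

Measured so far:
compound 1 `COc1ccc(-c2c(S(=O)(=O)c3cc(F)cc(F)c3)cnc3cc(F)ccc23)cc1`, 1.51 mL/min
compound 2 `COc1ccc(-c2c(S(=O)(=O)c3cccc(C#N)c3)cnc3cc(F)ccc23)cc1`, 0.92 mL/min

Both numbers come from an ADME assay on microsomes from liver (Homo sapiens) for metabolic stability, tested at 2.5 uM; on this read-out higher numbers stand for fast clearance and lower numbers for slow clearance. Among the compounds with values here, compound 2 holds the lowest of the two numbers, with compound 1 nearest; the only step, a 1.6-fold lower number from compound 1 to compound 2 (0.22 log units; within the scatter), stays within the scatter. Compound 3 `COc1ccc(-c2c(S(=O)(=O)c3ccc(C)c(C)c3)cnc3cc(F)ccc23)cc1` differs from compound 2 by 3,4-dimethylphenyl in place of 3-cyanophenyl on a sulfonyl sulfur. Within the data shown here, no measured step bears directly on this change; the single step seen, from one aryl group on the sulfonyl sulfur to another, was within the scatter. Compound 3 is therefore expected to give 1.3 mL/min (range 0.6 mL/min to 2.8 mL/min), which would be a 1.4-fold higher number from compound 2 to compound 3 (0.15 log units; within the scatter), a step not expected to exceed the scatter.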

Compound 3, intrinsic clearance in a liver preparation (reported as CLH), per the amount of preparation that the assay uses: 4.13 mL/min
The estimate for compound 3 lay 3.2-fold (0.50 log units) below the measured number; the measured number lies above the stated range.
By their numbers in this assay, from the lowest: compounds 2 and 1 (each within the scatter of the next); then compound 3.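

In this assay, the aryl group on the sulfonyl sulfur now makes a difference beyond the scatter: 3,4-dimethylphenyl in place of 3-cyanophenyl gives a 4.5-fold higher number from compound 2 to compound 3 (0.65 log units; beyond the scatter) and, in place of 3,5-difluorophenyl, gives a 2.7-fold higher number from compound 1 to compound 3 (0.44 log units; beyond the scatter) as well. Within the data shown here, the position is therefore not indifferent to this group, which the one earlier step, within the scatter, could not show. No data at hand account for the rise.

As far as these compounds go, whether a single methyl group would give a step of the same size remains open. So does the outcome with a methoxy group, an amine or a carboxylic acid on this aryl ring.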